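From Compound 2 to Compound 3: an Ethylsulfanyl Extension

The source may hold more compounds than are shown below. What is called first, only, known or untested is meant among the compounds shown, and "the series" means these compounds.

Measured so far:
compound 1, `Nc1nc2ccc(OCC(F)(F)C(F)(F)F)cc2s1`; in a functional assay on the whole organism with Rattus norvegicus as the target (a higher number here means that more compound is needed for the effect, a lower number that less compound is needed), compound 1 gives 7.5 mg/kg
compound 2, `CCn1c(=N)sc2cc(OC(F)(F)F)ccc21`; in this assay compound 2 gives 5 mg/kg

Of these two numbers, compound 2 has the lowest, and its nearest neighbour is compound 1, whose number is higher by a margin that lies within the usual scatter, so no order between the two can be claimed. Compound 3, `CCSCCn1c(=N)sc2cc(OC(F)(F)F)ccc21`, has not yet been tested in this assay. It differs from compound 2 in one place: ethylsulfanyl in place of hydrogen on a saturated chain carbon, two bonds along the chain from an aromatic nitrogen. Among the measured compounds shown here, no measured pair in this set shows what such an addition does, so the direction of the step is open. The step that the estimate means, a 1.2-fold higher number from compound 2 to compound 3 (0.08 log units; within the scatter), is expected to be small, if anything toward a somewhat higher dose, and not clearly beyond the scatter. For compound 3 the estimate in this assay is 6 mg/kg, with a range from 2.5 mg/kg to 15 mg/kg.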

Compound 3, dose for half-maximal effect: 2.2 mg/kg
The estimate for compound 3 lay 2.7-fold (0.44 log units) above the measured number, and the stated range ends above it.
By their numbers in this assay, from the lowest: compound 3; then compounds 2 and 1 (each within the scatter of the next).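

Extending the ethyl on the aromatic nitrogen to 2-(ethylsulfanyl)ethyl gives, in this assay, a 2.3-fold lower number from compound 2 to compound 3 (0.36 log units; beyond the scatter) and this is the first step in the set that can be read beyond the scatter. Compound 2 and compound 1 could not be put in order, and they differ in more than one place, so the set held no single change with a readable direction until now. This saturated chain carbon, two bonds along the chain from an aromatic nitrogen, therefore accepts ethylsulfanyl in place of hydrogen, and less compound is needed for the effect, although this rests on one pair and a modest step.

Whether the sulfur matters or the extra chain alone does stays open, since a plain longer carbon chain, an ethoxy group or an amine at the same place is not among the compounds shown. Nothing in the material at hand accounts for the step.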